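A few compounds are considered here, and "the series" means these few. Any claim that something is new, unique, unknown or untested is made for them only; others in the source may bear on it.

Measured so far in a functional assay on A549 cells (Homo sapiens) for antiproliferative activity, read by MTT assay, with a stated time of 72 h; on this read-out lower numbers stand for stronger inhibition and higher numbers for weaker inhibition:
Compound 1 `COc1cc(-c2ncnn2-c2cccc(F)c2)cc(OC)c1OC`: > 10000 nM
Compound 2 `COc1cc(-c2ncnn2-c2cccc(N)c2)cc(OC)c1OC`: > 10000 nM
Compound 3 `COc1cc(-c2ncnn2-c2ccccc2)cc(OC)c1OC`: > 10000 nM

Each of these entries is a limit of the assay and not a number, and the series shares a single ceiling: the limit of > 10000 nM in this assay, at which 3 of the 3 values shown sit. Compound 3 therefore has no measured position of its own. Compound 3 is reported at > 10000 nM, which is a limit.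

The next compound, compound 4 `COc1cc(-c2ncnn2-c2cccc([N+](=O)[O-])c2)cc(OC)c1OC`, carries nitro in place of hydrogen on an aromatic carbon. The measured steps that bear on this change are a step that the two limits leave unreadable from compound 1 to compound 3, a step that the two limits leave unreadable from compound 2 to compound 3 and a step that the two limits leave unreadable from compound 1 to compound 2. All three swap one group for another at the same place, and none has a size that can be read. The series thus offers no measured effect to carry over to nitro, and compounds 1, 2 and 3 give no counterexample to a flat picture. No step beyond the scatter is expected in this assay, and the likeliest report for compound 4 is the same limit. The expected step is a step that the limit leaves unreadable from compound 3 to compound 4. For compound 4 the estimated value is 15000 nM, with an expected range from 6000 nM to 50000 nM.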

Compound 4, half-maximal inhibitory concentration: > 10000 nM
Compound 4: a limit, no number; the forecaster's own chance of this, stated with the estimate: 85%; the middle value is on the limit's open side.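

In this assay compound 4 gives > 10000 nM, which is a limit and not a number. Going by these compounds alone, no step between compound 4 and compound 1, compound 2 or compound 3 can be read, because all four compounds sit at one ceiling: the limit of > 10000 nM in this assay, at which 4 of the 4 values shown sit. The compounds shown leave open whether fluoro, amino, nitro and hydrogen at this place differ at all in this assay.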